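Alkylamine-to-cycloalkylamine change in a nucleoside series

The source may report more compounds than this note shows. Statements on the series, on what has been measured and on what is new or still open speak of the compounds shown alone.

Measured so far:
compound 1, `CCCNc1nc2c(SCc3ccccc3)ncnc2n1C1O[C@H](CO)[C@@H](O)[C@H]1O`: 5.3 nM in an assay on cell membranes for binding affinity to Equilibrative nucleoside transporter 1 (Homo sapiens); on this read-out higher numbers stand for weaker inhibition and lower numbers for stronger inhibition
compound 2, `CCCCCCNc1nc2c(SCc3ccccc3)ncnc2n1C1O[C@H](CO)[C@@H](O)[C@H]1O`: 3.7 nM in this assay
compound 3, `CCC(C)CNc1nc2c(SCc3ccccc3)ncnc2n1C1O[C@H](CO)[C@@H](O)[C@H]1O`: 3.6 nM in this assay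

Compound 3 gives the lowest of the three numbers, yet its steps to compound 2 and to compound 1 both lie within the scatter, so no order among the three can be drawn. Compound 4, `OC[C@H]1OC(n2c(NC3CCCC3)nc3c(SCc4ccccc4)ncnc32)[C@H](O)[C@@H]1O`, differs from compound 3 by cyclopentyl in place of 2-methylbutyl on a nitrogen on an aromatic ring. The step that bears most directly on this is a 1.0-fold lower number from compound 2 to compound 3 (0.01 log units; within the scatter), an exchange of one chain for another on the same nitrogen that stayed within the scatter; a 1.4-fold lower number from compound 1 to compound 2 (0.16 log units; within the scatter) and a 1.5-fold lower number from compound 1 to compound 3 (0.17 log units; within the scatter) likewise stayed within it. Replacing the branched chain with a ring on that nitrogen is therefore expected to give no step beyond the scatter in this assay, a 1.1-fold higher number from compound 3 to compound 4 (0.05 log units; within the scatter). Compound 4 is expected near 4 nM, within 1.8 nM to 9 nM.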

Compound 4, inhibition constant: 0.64 nM
Compound 4: middle estimate off by 6.3-fold (0.80 log units), on the high side; the whole stated range lies above it.
By their numbers in this assay, from the lowest: compound 4; then compounds 3, 2 and 1 (each within the scatter of the next).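

At this nitrogen on an aromatic ring, the open chains showed no step beyond the scatter, whereas cyclopentyl stands apart from all three in this assay (a 5.6-fold lower number from compound 3 to compound 4 (0.75 log units; beyond the scatter); a 5.8-fold lower number from compound 2 to compound 4 (0.76 log units; beyond the scatter); an 8.3-fold lower number from compound 1 to compound 4 (0.92 log units; beyond the scatter)). The change from 2-methylbutyl to cyclopentyl leaves the carbon count unchanged and adds a ring, so chain size alone does not track these numbers across the series. No supporting evidence accounts for the step.

As far as these compounds go, whether this lower number is specific to cyclopentyl remains open. Cyclobutyl, cyclohexyl or a tetrahydrofuran ring on the same nitrogen would test that.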